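Working notes: replacing the amide substituent of compound 3

A few compounds are considered here, and "the series" means these few. Any claim that something is new, unique, unknown or untested is made for them only; others in the source may bear on it.

Measured so far in a physicochemical assay for solubility, read by spectrophotometry, measured as kinetic solubility, at pH 8, tested at 500 uM; a lower number here means a less soluble compound, a higher number a more soluble compound
- compound 1 `CN(Cc1cncnc1)S(=O)(=O)c1ccccc1Nc1cc(-c2ccc3ccn(C)c3c2)c2nccnc2c1` gives 3 ug/mL
- compound 2 `CNC(=O)c1ccncc1Nc1cc(-c2ccc3ccn(C)c3c2)c2nccnc2c1` gives 4 ug/mL
- compound 3 `Cn1ccc2ccc(-c3cc(Nc4cnccc4C(=O)NCc4cncnc4)cc4nccnc34)cc21` gives 233 ug/mL

Compound 3 holds the highest of the three numbers in this assay and lies beyond the scatter from both other compounds. Compound 4 `CN1CCC(NC(=O)c2ccncc2Nc2cc(-c3ccc4ccn(C)c4c3)c3nccnc3c2)CC1` is next to be read, and the change from compound 3 is 1-methylpiperidin-4-yl in place of (pyrimidin-5-yl)methyl on an amide-type nitrogen with the carbonyl kept in place.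

Among the measured compounds shown here, one measured step bears on this change. The step of a 58-fold higher number from compound 2 to compound 3 (1.77 log units; beyond the scatter) is large and beyond the scatter, and it came with pyrimidin-5-yl in place of hydrogen on a saturated chain carbon. Compound 4 gives up that pyrimidin-5-yl, so a lower number is the likelier direction. For the measured compounds named here, it does not return to the substituent of compound 2, however, and no measured compound carries 1-methylpiperidin-4-yl. The evidence is therefore thin, and the range has to stay wide. The expected change is a 1.6-fold lower number from compound 3 to compound 4 (0.19 log units; within the scatter) and a fall back to the level of compound 2 is not expected. For compound 4 the estimated value is 150 ug/mL (expected range 40 ug/mL to 260 ug/mL).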

Compound 4, solubility: 246 ug/mL
Compound 4: middle estimate off by 1.6-fold (0.21 log units), on the low side; measured number inside the range.
By their numbers in this assay, from the lowest: compounds 1 and 2 (each within the scatter of the next); then compounds 3 and 4 (each within the scatter of the next).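

In this assay, (pyrimidin-5-yl)methyl and 1-methylpiperidin-4-yl on the amide-type nitrogen cannot be told apart, with a 1.1-fold higher number from compound 3 to compound 4 (0.02 log units; within the scatter), so the aromatic ring with 2 hetero atoms is not needed to reach the level of compound 3. The second new step, a 62-fold higher number from compound 2 to compound 4 (1.79 log units; beyond the scatter), joins a 58-fold higher number from compound 2 to compound 3 (1.77 log units; beyond the scatter) in showing a large rise over the methyl amide from two different substituents, each with 7 heavy atoms and a six-membered ring, one aromatic and one non-aromatic. No supporting data on these compounds accounts for why the two substituents read alike.

The compounds shown leave open whether the ring nitrogens matter at all at this position, since a cyclohexyl group, whose ring holds carbon only, would separate ring size from hetero atom content. They also leave open whether a ring is needed, which an open-chain amine such as 2-(dimethylamino)ethyl on the same amide-type nitrogen would address.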